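Swapping a side chain and watching cell toxicity

The source may hold more compounds than are shown below. What is called first, only, known or untested is meant among the compounds shown, and "the series" means these compounds.

Measured so far in an ADME assay on HEK293-A cells (Homo sapiens) for cytotoxicity, read by MTT assay, with a stated time of 48 h; a lower number here means a stronger inhibitor, a higher number a weaker inhibitor:
compound 1 `COC(=O)CC1CCN(C[C@H]2CN(c3ccc(-n4cc(-c5ccccn5)cn4)c(F)c3)C(=O)O2)CC1`: 224 ug/mL
compound 2 `O=C1CNC(=O)N1C[C@H]1CN(c2ccc(-n3cc(-c4ccccn4)cn3)c(F)c2)C(=O)O1`: > 400 ug/mL, a limit of the assay rather than a number
compound 3 `CN(C)S(=O)(=O)NC[C@H]1CN(c2ccc(-n3cc(-c4ccccn4)cn3)c(F)c2)C(=O)O1`: 249 ug/mL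

Compound 3 holds the higher of the two numbers given, with compound 1 nearest: a 1.1-fold higher number from compound 1 to compound 3 (0.05 log units; within the scatter). Compound 2 sits at the limit of > 400 ug/mL in this assay, at which 1 of the 3 values shown sits.

Compound 4 `CONC(=O)[C@H]1CN(c2ccc(-n3cc(-c4ccccn4)cn3)c(F)c2)C(=O)O1` carries the change (methoxycarbamoyl in place of ((dimethylsulfamoyl)amino)methyl on a saturated ring carbon). Among the measured compounds shown here, every measured step so far swaps the group on the chain carbon instead, and none moved beyond the scatter: a 1.1-fold higher number from compound 1 to compound 3 (0.05 log units; within the scatter) and an at least 1.6-fold lower number from compound 2 to compound 3 (0.20 log units; that floor lies within the scatter). For the measured compounds named here, with no step at this ring carbon available, compound 4 is expected to stay close to compound 3, giving a 1.0-fold higher number from compound 3 to compound 4 (0.00 log units; within the scatter). Compound 4 is therefore estimated at 250 ug/mL, between 120 ug/mL and 450 ug/mL.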

Compound 4, half-maximal inhibitory concentration: > 400 ug/mL
Compound 4: a limit, no number (the forecaster's own chance of this, stated with the estimate: 30%); middle value at least 1.6-fold (0.20 log units) away from the limit.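

Compound 4 is the only compound shown with a change on the saturated ring carbon itself, and in this assay compound 4 gives > 400 ug/mL, a limit of the assay rather than a number. Methoxycarbamoyl there gives an at least 1.6-fold higher number from compound 3 to compound 4 (0.20 log units; that floor lies within the scatter) and an at least 1.7-fold higher number from compound 1 to compound 4 (0.25 log units; that floor lies within the scatter), so neither floor establishes a real change, though the true steps could be larger. The step between compound 2 and compound 4 cannot be read: the limit of > 400 ug/mL in this assay, at which 2 of the 4 values shown sit.

On these data alone, how far compound 4 lies past its limit remains open, as does whether an amine or a carboxylic acid on this ring carbon would give a measurable number.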